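This account rests on a few compounds, and the source may have more. Where it says the series, first, only, none or still open, it means among the compounds named here.

Compound 1 `CC(C)OC(=O)NCCS(=O)(=O)NC(=O)c1ccc(Nc2nc(NC3(c4ccc(Cl)cc4)CC3)nc(OCC(F)(F)F)n2)cc1`: 73%
Compound 2 `O=C(NS(=O)(=O)c1ccccc1)c1ccc(Nc2nc(NC3(c4ccc(Cl)cc4)CC3)nc(OCC(F)(F)F)n2)cc1`: 100%
Compound 3 `CC(C)(C)NC(=O)NCCS(=O)(=O)NC(=O)c1ccc(Nc2nc(NC3(c4ccc(Cl)cc4)CC3)nc(OCC(F)(F)F)n2)cc1`: 93%

In an ADME assay on microsomes from liver (Rattus norvegicus) for metabolic stability, with a stated time of 10 min (on this read-out lower numbers stand for a less stable compound and higher numbers for a more stable compound), compound 2 stands at the upper end of the three numbers: compound 3 lies within the scatter of it (a number 7 percentage points lower from compound 2 to compound 3 (within the scatter)), while compound 1 is set apart (a number 27 percentage points higher from compound 1 to compound 2 (beyond the scatter)). Compound 4 `NCCS(=O)(=O)NC(=O)c1ccc(Nc2nc(NC3(c4ccc(Cl)cc4)CC3)nc(OCC(F)(F)F)n2)cc1` has not yet been measured in this assay. Its change from compound 2 is 2-aminoethyl in place of phenyl on a sulfonyl sulfur. Going by the values given here, two measured steps bear on it, both exchanging the phenyl on the sulfonyl sulfur for a two-carbon chain: one step lowered the number beyond the scatter, the other stayed within it. A small drop, or none beyond the scatter, is therefore expected in this assay, namely a number 15 percentage points lower from compound 2 to compound 4 (beyond the scatter). Compound 4 is estimated at 85%, with a range from 62% to 100%.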

Compound 4, percent of the compound remaining: 100%
For compound 4 the middle estimate is 15 percentage points below the measured one; measured number inside the range.
By their numbers in this assay, from the lowest: compound 1; then compounds 3, 2 and 4 (each within the scatter of the next).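

In this assay, 2-aminoethyl on the sulfonyl sulfur holds the number set by phenyl (no change at the digits printed from compound 2 to compound 4 (within the scatter)), so this position accepts a chain without a ring that carries a hydrogen-bond donor. On the two-carbon chain, the free amine stays within the scatter of the (tert-butyl)carbamoyl-capped compound (a number 7 percentage points higher from compound 3 to compound 4 (within the scatter)) but stands apart from the isopropoxycarbonyl-capped one (a number 27 percentage points higher from compound 1 to compound 4 (beyond the scatter)), which singles out that cap among the three chains shown. Nothing available here accounts for these numbers.

Still open, on these data alone, is whether a longer chain ending in an amine would hold the number. The same question applies to a carboxylic acid at the end of the two-carbon chain.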